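The source may hold more compounds than are shown below. What is called first, only, known or untested is meant among the compounds shown, and "the series" means these compounds.

For the measured compounds named here, compound 1 `NS(=O)(=O)Oc1ccc2c(c1)CN(C(=O)c1ccc(N3CCCCC3)cc1)CC2` is the strongest of the three measured members in an assay on HEK293 cells for inhibition of Steryl-sulfatase (Homo sapiens), tested at 0.1 uM (a lower number here means a weaker effect, a higher number a stronger effect of the compound at the concentration tested), where compound 1 gives 11.5%. Compound 2 `NS(=O)(=O)Oc1ccc2c(c1)CN(C(=O)c1cccc(N3CCC(N4CCCCC4)CC3)c1)CC2` gives 0% and compound 3 `CCN(Cc1ccccc1)Cc1ccc(CN2CCc3ccc(OS(N)(=O)=O)cc3C2)cc1` gives 1% in this assay, both steps from compound 1 lying beyond the scatter. Compound 4 `CCN(Cc1ccccc1)c1ccc(C(=O)N2CCc3ccc(OS(N)(=O)=O)cc3C2)cc1` remains to be measured. It differs from compound 1 in one place: benzyl(ethyl)amino in place of piperidin-1-yl on an aromatic carbon. Going by the values given here, no measured pair isolates this change. Compound 3 carries the same benzyl(ethyl)amino group on a different core and reaches only 1% in this assay. With all three measured values low, compound 4 is expected to stay at the weak end, the expected step being a number 6.5 percentage points lower from compound 1 to compound 4 (within the scatter), downward or not beyond the scatter. The estimate for compound 4 in this assay is 5%, within 0% to 18%.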

Compound 4, a percentage reported as inhibition, at one concentration (the size of the read-out at that concentration, not a potency): 66.9%
For compound 4 the middle estimate is 61.9 percentage points below the measured one; measured number outside the range, above it.
By their numbers in this assay, from the lowest: compounds 2 and 3 (each within the scatter of the next); then compound 1; then compound 4.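

In this assay the group on this aromatic carbon, para to a large group, strongly sets the read-out: benzyl(ethyl)amino in place of piperidin-1-yl gives a number 55.4 percentage points higher from compound 1 to compound 4 (beyond the scatter) on the shared core. For the compounds shown here, the change swaps a six-membered non-aromatic ring for an open amine carrying a six-membered aromatic ring, and it is the only single-place change so far. Nothing at hand accounts for the size of this step.

Which part of the entering group carries the gain stays open: diethylamino would drop the aromatic ring, and benzyl(methyl)amino would shorten the chain. From the compounds shown here alone, whether the gain holds on other cores also stays open.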